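This account rests on a few compounds, and the source may have more. Where it says the series, first, only, none or still open, it means among the compounds named here.

In a functional assay on HeLa cells (Homo sapiens) for antiproliferative activity, read by CCK-8 assay, with a stated time of 72 h, tested at 2 uM (a higher number here means a stronger effect of the compound at the concentration tested, a lower number a weaker effect), compound 1 `Nc1ccccc1NC(=O)c1ccc(CSC(=S)N2CCN(Cc3ccccn3)CC2)cc1` gives 14.2%, and compound 2 `Nc1ccccc1NC(=O)c1ccc(CSC(=S)N2CCN(c3ccncc3)CC2)cc1` gives 77%. Compound 3 `Nc1ccccc1NC(=O)c1ccc(CSC(=S)N2CCN(Cc3ccccc3)CC2)cc1` gives 20.6%, the second highest of the three numbers: the step of a number 6.4 percentage points higher from compound 1 to compound 3 (within the scatter) stays within the scatter, whereas the step of a number 56.4 percentage points lower from compound 2 to compound 3 (beyond the scatter) lies beyond it. Compound 4 `Nc1ccccc1NC(=O)c1ccc(CSC(=S)N2CCN(Cc3cccnc3)CC2)cc1` differs from compound 3 in one place: pyridin-3-yl in place of phenyl on a saturated chain carbon bound to an amine nitrogen in a ring. Of the measured steps, the only one that touches the same place, a group on a saturated chain carbon bound to an amine nitrogen in a ring, is a number 6.4 percentage points higher from compound 1 to compound 3 (within the scatter). The steps of a number 62.8 percentage points higher from compound 1 to compound 2 (beyond the scatter) and a number 56.4 percentage points lower from compound 2 to compound 3 (beyond the scatter) exchange a group sitting directly on the amine nitrogen in a ring and say less about this change. Because the step of a number 6.4 percentage points higher from compound 1 to compound 3 (within the scatter) stayed within the scatter, the expected step is a number 1.4 percentage points higher from compound 3 to compound 4 (within the scatter), none beyond the scatter. Compound 4 is therefore estimated at 22%, with a range from 8% to 42%.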

Compound 4, a percentage reported as inhibition, at one concentration (the size of the read-out at that concentration, not a potency): 69.7%
Compound 4: the middle estimate sits 47.7 percentage points below what was measured; the measured number lies above the stated range.
By their numbers in this assay, from the lowest: compounds 1 and 3 (each within the scatter of the next); then compounds 4 and 2 (each within the scatter of the next).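

On a saturated chain carbon bound to an amine nitrogen in a ring, the choice of aromatic ring now matters: pyridin-3-yl in place of phenyl gives a number 49.1 percentage points higher from compound 3 to compound 4 (beyond the scatter) and pyridin-3-yl in place of pyridin-2-yl gives a number 55.5 percentage points higher from compound 1 to compound 4 (beyond the scatter) in this assay. Phenyl and pyridin-2-yl had stayed within the scatter, so adding a ring nitrogen does not by itself raise the number. (Pyridin-3-yl)methyl also stays level with pyridin-4-yl, with a number 7.3 percentage points lower from compound 2 to compound 4 (within the scatter) within the scatter. No measurement shown explains these differences. As far as these compounds go, whether (pyridin-4-yl)methyl would match (pyridin-3-yl)methyl remains open.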